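Series notes: a repeated methoxy step toward compound 4

A few compounds are considered here, and "the series" means these few. Any claim that something is new, unique, unknown or untested is made for them only; others in the source may bear on it.

Measured in a functional assay on HCT-116 cells (Homo sapiens) for inhibition, read by sulforhodamine B assay, with a stated time of 48 h, tested at 50 uM; a higher number here means more inhibition of growth at the concentration tested, a lower number less inhibition of growth:
- compound 1, `COc1cccc(/C=C/C(=O)/C=C/c2ccc(OCc3cn(CCOc4cc(=O)oc5ccccc45)nn3)c(OC)c2)c1`: 70%
- compound 2, `COc1cccc(/C=C/C(=O)/C=C/c2ccc(OCc3cn(CCCOc4cc(=O)oc5ccccc45)nn3)c(OC)c2)c1`: 55%
- compound 3, `COc1ccc(/C=C/C(=O)/C=C/c2ccc(OCc3cn(CCOc4cc(=O)oc5ccccc45)nn3)c(OC)c2)cc1OC`: 82%

Compound 3 differs from compound 1 only by methoxy in place of hydrogen on an aromatic carbon. The step is a number 12 percentage points higher from compound 1 to compound 3 (beyond the scatter), a modest gain beyond the scatter. Compound 2 shares no counted single-point difference with compound 1; the difference between the two cores is not broken down here. Its value in this assay stands lowest of the three, with compound 1 nearer and compound 3 further away, both gaps beyond the scatter.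

Compound 4, `COc1ccc(/C=C/C(=O)/C=C/c2ccc(OCc3cn(CCCOc4cc(=O)oc5ccccc45)nn3)c(OC)c2)cc1OC`, is not yet measured. It differs from compound 2 by methoxy in place of hydrogen on an aromatic carbon; the surroundings of the place are the same as for the step from compound 1 to compound 3, so this is the same change made on the core of compound 2. For the measured compounds named here, only one earlier instance exists, so the expectation rests on that single step.

For compound 4 in this assay the expected step is a number 12 percentage points higher from compound 2 to compound 4 (beyond the scatter), about the size of a number 12 percentage points higher from compound 1 to compound 3 (beyond the scatter). The estimate for compound 4 is 67%, between 55% and 79%.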

Compound 4, percent growth inhibition at one concentration: 67%
Beside the measured number, compound 4's estimate shows no gap at the digits printed; low and high end bracket the measured number.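

In this assay, the change from 3-methoxyphenyl to 3,4-dimethoxyphenyl on the core of compound 2 gives a number 12 percentage points higher from compound 2 to compound 4 (beyond the scatter), and the step matches the one on the core of compound 1: the same change on two cores in this assay, a number 12 percentage points higher (beyond the scatter) from compound 1 to compound 3 and a number 12 percentage points higher (beyond the scatter) from compound 2 to compound 4, 0 percentage points apart, within the scatter of two such steps

Within these two matched pairs, the methoxy step therefore carries from one core to the other with no size difference that can be told from the scatter. For the compounds shown here, this is a result from only two pairs, read as growth inhibition at a single concentration in one cell line, so it does not establish that the step would hold on any further core or under other test conditions, and it gives no explanation for the match.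

Still open, from the compounds shown here alone, is whether a hydroxy group, a chlorine atom or an amine in the place of the added methoxy would give a step of similar size. Going by these compounds alone, also open is whether the step would persist with a longer chain than the one in compound 4.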